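Taking the chloro group off compound 2

The source may hold more compounds than are shown below. What is called first, only, known or untested is meant among the compounds shown, and "the series" means these compounds.

In a functional assay on cells (Erythrocyte, Rattus norvegicus) for inhibition, read by hemolysis, with a stated time of 1 h (a higher number here means a weaker inhibitor, a lower number a stronger inhibitor), compound 1 `COc1cc(OC)c(OC)cc1/C=C/C(=O)c1ccc(Cl)cc1` gives 2.3 ug/mL and compound 2 `COc1cc(OC)c(OC)cc1/C=C/C(=O)c1ccc(Cl)c([N+](=O)[O-])c1` gives 2.15 ug/mL on the same read-out, so compound 2 stands level with compound 1. Compound 3 `COc1cc(OC)c(OC)cc1/C=C/C(=O)c1cccc([N+](=O)[O-])c1` carries the change hydrogen in place of chloro on an aromatic carbon from compound 2, hydrogen in place of chloro on an aromatic carbon. Among the measured compounds shown here, the only measured step is a different change, nitro in place of hydrogen on an aromatic carbon, and it came to a 1.1-fold lower number from compound 1 to compound 2 (0.03 log units; within the scatter) in this series. For the measured compounds named here, no measured step removes the chloro group, and this assay is expected to show no shift beyond the scatter. The expected step is a 1.2-fold higher number from compound 2 to compound 3 (0.07 log units; within the scatter) and no more. For compound 3 the estimate is 2.5 ug/mL with an expected range from 1.2 ug/mL to 5 ug/mL in this series.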

Compound 3, half-maximal inhibitory concentration: 2.21 ug/mL
The estimate for compound 3 lay 1.1-fold (0.05 log units) above the measured number; low and high end bracket the measured number.
By their numbers in this assay, from the lowest: compounds 2, 3 and 1 (each within the scatter of the next).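

With the nitro group present, this assay gives a 1.0-fold higher number from compound 2 to compound 3 (0.01 log units; within the scatter), so hydrogen and chloro are not told apart on this aromatic carbon, ortho to a nitro group and para to a large group. The earlier step covered only the nitro group entering with chloro held in place; this one shows that the number holds without chloro. No measurement available here offers a reason for this result. The compounds shown leave open what an amine or a carboxylic acid on this carbon would give, and what a compound carrying neither chloro nor nitro would give.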